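This account rests on a few compounds, and the source may have more. Where it says the series, first, only, none or still open, it means among the compounds named here.

In a functional assay on Gurav cells (Homo sapiens) for inhibition, read by sulforhodamine B assay (a higher number here means a weaker inhibitor of growth, a lower number a stronger inhibitor of growth), compound 1 (`Cc1ccc2[nH]c(-c3ccc(-c4ccc(-c5ccc(N(C)C)cc5)cc4)cc3)nc2c1`) gives 6240 nM, compound 2 (`COc1ccc(-c2ccc(-c3ccc(-c4nc5cc(C)ccc5[nH]4)cc3)cc2)cc1OC`) gives 1310 nM and compound 3 (`Cc1ccc2[nH]c(-c3ccc(-c4ccc(-c5ccccc5)cc4)cc3)nc2c1`) gives 3310 nM. Compound 3 therefore stands within the scatter of compound 1, with a higher number than compound 2. Compound 4 (`Cc1ccc2[nH]c(-c3ccc(-c4ccc(-c5ccc(F)cc5)cc4)cc3)nc2c1`) has fluoro in place of hydrogen on an aromatic carbon, para to a large group: fluoro in place of hydrogen on an aromatic carbon. For the measured compounds named here, two measured steps bear on this change, though neither involves fluoro. Hydrogen in place of dimethylamino gave a 1.9-fold lower number from compound 1 to compound 3 (0.28 log units; within the scatter), and phenyl in place of 3,4-dimethoxyphenyl gave a 2.5-fold higher number from compound 2 to compound 3 (0.40 log units; beyond the scatter). With only these modest or smaller steps as a guide, no change beyond the scatter is expected, and the expected step is a 1.1-fold lower number from compound 3 to compound 4 (0.04 log units; within the scatter). For compound 4 the estimated value is 3000 nM, within a range of 1500 nM to 6000 nM.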

Compound 4, concentration for 50% growth inhibition: 16500 nM
The estimate for compound 4 lay 5.5-fold (0.74 log units) below the measured number, and the stated range ends below it.
By their numbers in this assay, from the lowest: compound 2; then compounds 3 and 1 (each within the scatter of the next); then compound 4.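

In this assay, fluoro in place of hydrogen at this position gives a 5.0-fold higher number from compound 3 to compound 4 (0.70 log units; beyond the scatter), so even this one-atom change on an aromatic carbon, para to a large group, matters here. Fluoro in place of dimethylamino gives a 2.6-fold higher number from compound 1 to compound 4 (0.42 log units; beyond the scatter), and 4-fluorophenyl in place of 3,4-dimethoxyphenyl gives a 13-fold higher number from compound 2 to compound 4 (1.10 log units; beyond the scatter), which leaves compound 4 the weakest inhibitor of growth of the four. No measurement at hand accounts for this.

From the compounds shown here alone, whether chloro, methyl or a single methoxy at this place would behave like fluoro or like hydrogen remains open.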